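Methoxy to Ethoxy on the Shared Core

This account rests on a few compounds, and the source may have more. Where it says the series, first, only, none or still open, it means among the compounds named here.

Compound 1 `CCCC(Nc1cncc(-c2ccc(O)c(OC)c2)n1)c1cccc(OC)c1`: 10000 nM
Compound 2 `CCCC(Nc1cncc(-c2ccc(O)c(OC)c2)n1)c1cccc(Cl)c1`: 1000 nM
Compound 3 `CCCC(Nc1cncc(-c2ccc(O)c(OC)c2)n1)c1cccnc1`: 300 nM

Of the compounds shown here, three sharing one core have been measured in a functional assay on PC-3 cells (Homo sapiens) for cytotoxicity, read by MTT assay, with a stated time of 72 h; on this read-out lower numbers stand for stronger inhibition and higher numbers for weaker inhibition. Compound 3 stands lowest of the three; its nearest neighbour is compound 2, and the gap between them is a 3.3-fold lower number from compound 2 to compound 3 (0.52 log units; beyond the scatter). Compound 1 lies furthest away, with a 33-fold lower number from compound 1 to compound 3 (1.52 log units; beyond the scatter). The remaining step, a 10-fold lower number from compound 1 to compound 2 (1.00 log units; beyond the scatter), shows the effect of a chloro in place of methoxy on an aromatic carbon.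

Compound 4 `CCCC(Nc1cncc(-c2ccc(O)c(OCC)c2)n1)c1cccnc1` differs from compound 3 in one place: methyl in place of hydrogen on a saturated chain carbon bound to an oxygen on an aromatic ring, so that the methoxy on the phenol-bearing ring becomes an ethoxy. For the measured compounds named here, none of the measured steps touches this part of the molecule; all three vary the aryl group on the saturated chain carbon bound to the ring nitrogen. Going by the values given here, there is therefore nothing among the measured compounds that speaks for a shift in this assay in either direction, and the expectation is a step of no more than the usual scatter.

On that basis compound 4 is estimated at 300 nM, with a range from 100 nM to 1000 nM. This expected step, no change at the digits printed from compound 3 to compound 4 (within the scatter), is an estimate and rests only on the value of compound 3.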

Compound 4, half-maximal inhibitory concentration: 1000 nM
Compound 4: the middle estimate sits 3.3-fold (0.52 log units) below what was measured; the range from low to high includes it.
By their numbers in this assay, from the lowest: compound 3; then compounds 2 and 4 (each within the scatter of the next); then compound 1.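

Going from methoxy to ethoxy on the phenol-bearing ring gives, in this assay, a 3.3-fold higher number from compound 3 to compound 4 (0.52 log units; beyond the scatter), so a methyl added on a saturated chain carbon bound to an oxygen on an aromatic ring moves the read-out towards weaker inhibition. The earlier steps shown here all varied the aryl group on the saturated chain carbon bound to a nitrogen on an aromatic ring, and they said nothing about this other end of the molecule; this step shows that the alkoxy group there also bears on the number, even though the change is only a methyl. Nothing available explains why this methyl has that effect.

The compounds shown leave open whether the trend continues with a longer chain such as propoxy or reverses with a hydroxy group in place of the methoxy, since one step gives a direction only for this single change. They also leave open whether the same methyl would have a similar effect with the 3-chlorophenyl or 3-methoxyphenyl group in place of pyridin-3-yl.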